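The compounds below may be only part of what the source reports. "The series", "measured", "known", "first", "only" and "open" are said of these compounds alone.

Of the compounds shown here, three have so far been tested in an ADME assay on Vero cells (Chlorocebus sabaeus) for cytotoxicity, read by WST assay; on this read-out lower numbers stand for higher toxicity in this test and higher numbers for lower toxicity in this test. Compound 1 `COc1cccc2nc(Nc3cc(F)cc(F)c3)[nH]c(=O)c12` carries a methoxy group on its core. In this assay compound 1 gives > 25000 nM, which is a limit of the assay rather than a number. Compound 2 `O=c1[nH]c(Nc2cc(F)cc(F)c2)nc2cccc(O)c12` differs from compound 1 by hydrogen in place of methyl on an oxygen on an aromatic ring. In this assay compound 2 gives > 25000 nM, again only a limit. Between these two compounds the measured step is a step that the two limits leave unreadable from compound 1 to compound 2. Compound 3 `COc1cccc2nc(Nc3cc(Cl)cc(Cl)c3)[nH]c(=O)c12` also carries a methoxy group, but how the core of compound 1 and the core of compound 3 differ is not broken down here. In this assay compound 3 gives > 25000 nM, once more a limit. All of the values seen so far therefore share one feature: the limit of > 25000 nM in this assay, at which 3 of the 3 values shown sit.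

Compound 4 `O=c1[nH]c(Nc2cc(Cl)cc(Cl)c2)nc2cccc(O)c12` has not yet been measured. Compound 4 differs from compound 3 by hydrogen in place of methyl on an oxygen on an aromatic ring, and the place of this change is the same word for word as in the change from compound 1 to compound 2, so it is the same change made on a different core. Compound 4 is expected to show a step that the limit leaves unreadable from compound 3 to compound 4 in this assay, because the limit of > 25000 nM in this assay, at which 3 of the 3 values shown sit, describes every value in the set, including the pair in which this very change was made. Compound 4 is accordingly estimated to give 40000 nM in this assay, most likely as a limit rather than a number.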

Compound 4, half-maximal cytotoxic concentration: > 25000 nM
Compound 4: no number, only a limit; the forecaster's own chance of this, stated with the estimate: 85%; the middle value is on the limit's open side.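

In this assay compound 4 gives > 25000 nM as a limit and not a number. Among the compounds shown here, no step from compound 3 to compound 4 can be read, because this result stands where all the others do: the limit of > 25000 nM in this assay, at which 4 of the 4 values shown sit. The compounds shown leave open how far each lies from that limit, and so whether going from methoxy to hydroxy alters toxicity in this test at all.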